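Demethylation of a Pyrazole Urea Series and Cell Toxicity

The source may hold more compounds than are shown below. What is called first, only, known or untested is meant among the compounds shown, and "the series" means these compounds.

Compound 1 `COc1cc(-c2nn(-c3cccc(NC(=O)Nc4cc(C(F)(F)F)cc(C(F)(F)F)c4)c3)cc2-c2ccncc2)ccc1Cl` was tested in a functional assay on MDA-MB-435 cells (Homo sapiens) for inhibition, read by sulforhodamine B assay, with a stated time of 48 h (on this read-out higher numbers stand for lower toxicity in this test and lower numbers for higher toxicity in this test), where compound 1 gives 4460 nM. Compound 2 `O=C(Nc1cccc(-n2cc(-c3ccncc3)c(-c3ccc(Cl)c(O)c3)n2)c1)Nc1cc(C(F)(F)F)cc(C(F)(F)F)c1` carries the same core with hydrogen in place of methyl on an oxygen on an aromatic ring, and in this assay compound 2 gives 15600 nM. The measured step is a 3.5-fold higher number from compound 1 to compound 2 (0.54 log units; beyond the scatter). Compound 3 `COc1cc(-c2nn(-c3cccc(NC(=O)Nc4ccc(Cl)c(C(F)(F)F)c4)c3)cc2-c2ccncc2)ccc1Cl` differs from compound 1 in a way that is not broken down here. In this assay compound 3 reaches only a limit of the assay, > 32500 nM, so no number stands for it (the limit of > 32500 nM in this assay, at which 1 of the 3 values shown sits). Compound 4 `O=C(Nc1cccc(-n2cc(-c3ccncc3)c(-c3ccc(Cl)c(O)c3)n2)c1)Nc1ccc(Cl)c(C(F)(F)F)c1` is not yet measured; relative to compound 3 it carries hydrogen in place of methyl on an oxygen on an aromatic ring, the same kind of change as that from compound 1 to compound 2, at a place described in the same words. The expectation for compound 4 rests on the measured step from compound 1 to compound 2, which moved the number upward beyond the scatter, and on compound 3 sitting already at the limit; the expected step is a step that the limit leaves unreadable from compound 3 to compound 4. Compound 4 is therefore estimated at 70000 nM, with a range from 25000 nM to 250000 nM, and most likely only a limit will be reported.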

Compound 4, concentration lethal to 50% of the cells: 21500 nM
Compound 4: the middle estimate sits 3.3-fold (0.51 log units) above what was measured; the measured number lies below the stated range.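

In this assay, the exchange of methoxy for hydroxy gave an at least 1.5-fold lower number from compound 3 to compound 4 (0.17 log units; that floor lies within the scatter), so on this core the number did not rise as it had on the core of compound 1. Set side by side, the two steps show that this change does not carry over from one core to the other with the same outcome: the same change on two cores in this assay, a 3.5-fold higher number (0.54 log units; beyond the scatter) from compound 1 to compound 2 and an at least 1.5-fold lower number (0.17 log units; that floor lies within the scatter) from compound 3 to compound 4, at least 5.2-fold (0.72 log units) apart, beyond the scatter of two such steps Compound 3 has only a limit of the assay, > 32500 nM, so the true size of its step stays unknown, and two pairs cannot show which core is the typical one or why they part: the limit of > 32500 nM in this assay, at which 1 of the 4 values shown sits.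

The compounds shown leave open whether a third core would follow the step seen on the core of compound 1 or the one seen on the core of compound 3. They also leave open how the number would move with an amine or a carboxylic acid in place of the methoxy, or with a longer chain such as ethoxy on the same oxygen.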